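The source may hold more compounds than are shown below. What is called first, only, known or untested is meant among the compounds shown, and "the series" means these compounds.

Working notes on the series. Compound 1 `CC(C)C(Cc1ncc[nH]1)c1ccc(-c2ccc3cccc(F)c3c2)[nH]c1=O` is the reference point; in a functional assay on CHO cells for antagonist activity at prostaglandin E2 receptor EP3 subtype (Homo sapiens), read by cAMP accumulation (on this read-out lower numbers stand for stronger inhibition and higher numbers for weaker inhibition), compound 1 gives 76 nM, the second highest of the three numbers in hand. Compound 2 `CC(C)C(Nc1nnc[nH]1)c1ccc(-c2ccc3cccc(F)c3c2)[nH]c1=O` gives 185 nM in this assay, and compound 3 `CC(C)C(c1cnc(N)s1)c1ccc(-c2ccc3cccc(F)c3c2)[nH]c1=O` gives 39 nM. Both measured steps from compound 1 swap the same group on the saturated chain carbon bound to an aromatic carbon and a saturated chain carbon: a 2.4-fold higher number from compound 1 to compound 2 (0.39 log units; beyond the scatter), and a 1.9-fold lower number from compound 1 to compound 3 (0.29 log units; within the scatter). Compound 4 `CC(C)C(c1noc(=O)[nH]1)c1ccc(-c2ccc3cccc(F)c3c2)[nH]c1=O` has not yet been measured; relative to compound 1 the change is a group of 6 heavy atoms (2 carbon, 2 nitrogen, 2 oxygen; one five-membered aromatic ring with 3 hetero atoms) in place of a group of 6 heavy atoms (4 carbon, 2 nitrogen; one five-membered aromatic ring with 2 hetero atoms), on a saturated chain carbon bound to an aromatic carbon and a saturated chain carbon. The two measured swaps at that place moved the number in opposite directions and neither by much, so for compound 4 a step of at most modest size is expected in this assay, without a firm direction, the bearing steps being those from compound 1 to compound 2 and from compound 1 to compound 3. Compound 4 is estimated at about 70 nM (range 20 nM to 250 nM), which would mean a 1.1-fold lower number from compound 1 to compound 4 (0.04 log units; within the scatter).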

Compound 4, half-maximal inhibitory concentration: 41 nM
Beside the measured number, compound 4's estimate is 1.7-fold (0.23 log units) above it; measured number inside the range.
By their numbers in this assay, from the lowest: compounds 3, 4 and 1 (each within the scatter of the next); then compound 2.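

The new ring keeps the number in the same band as the other two: the data show a 1.9-fold lower number from compound 1 to compound 4 (0.27 log units; within the scatter) and a 1.1-fold higher number from compound 3 to compound 4 (0.02 log units; within the scatter) and so give no separation among the groups of compounds 1, 3 and 4 at this place. Against that, a 4.5-fold lower number from compound 2 to compound 4 (0.65 log units; beyond the scatter) is a step beyond the scatter between two groups that each hold a five-membered aromatic ring with 3 hetero atoms, so the count of ring hetero atoms alone does not set the number here. No supporting measurement accounts for these steps.

The compounds shown leave open whether a carboxylic acid or a plain amine on this saturated chain carbon would give a number like those of compounds 1, 3 and 4 or one like that of compound 2. Going by these compounds, whether a five-membered aromatic ring is needed here at all also remains open.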